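Pyridyl ether series: from compound 3 toward compound 4

This account rests on a few compounds, and the source may have more. Where it says the series, first, only, none or still open, it means among the compounds named here.

Three acids sharing a common core have numbers in a physicochemical assay for lipophilicity, read by LC-MS, in phosphate buffer, measured as octanol-water partition, with a stated time of 30 min, at pH 7.4, tested at 200 mM; on this read-out higher numbers stand for higher lipophilicity and lower numbers for lower lipophilicity. Compound 1 `Cn1c(COc2cccc(C(=O)O)c2)nc2ccc(Oc3ccc(Cl)c(F)c3)nc21` gives 2.2, compound 2 `Cn1c(COc2cccc(C(=O)O)c2)nc2cnc(Oc3ccc4c(c3)CCC4)cc21` gives 1.6, and compound 3 `Cn1c(COc2cccc(C(=O)O)c2)nc2ccc(Oc3ncccc3Cl)cc21` gives 1.1. Compound 3 stands lowest of the three, with compound 2 nearest and compound 1 furthest, both separated from it by more than the scatter.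

Compound 4 `Cc1cc(Cl)cnc1Oc1ccc2nc(COc3cccc(C(=O)O)c3)n(C)c2c1` differs from compound 3 in one place: 5-chloro-3-methylpyridin-2-yl in place of 3-chloropyridin-2-yl on an oxygen on an aromatic ring. The group that enters carries one more heavy atom than the one that leaves, with the same count of hydrogen-bond donors and acceptors and no change in charge. Among the measured compounds shown here, no measured pair in the set shows this change, so the size of the step cannot be read from the data.

The expectation is a modest upward move in this assay , a number 0.50 log units higher from compound 3 to compound 4 (beyond the scatter), beyond the scatter but well short of the gap between compound 3 and compound 1. Compound 4 is estimated at 1.6, within 1.2 to 2.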

Compound 4, distribution coefficient: 1.8
The estimate for compound 4 lay 0.20 log units below the measured number; measured number inside the range.
By their numbers in this assay, from the lowest: compound 3; then compounds 2 and 4 (each within the scatter of the next); then compound 1.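

Among the compounds shown here, on an oxygen on an aromatic ring, (5-chloro-3-methylpyridin-2-yl)oxy in place of (3-chloropyridin-2-yl)oxy gives the first single-place comparison: in this assay it amounts to a number 0.70 log units higher from compound 3 to compound 4 (beyond the scatter). This shows that a change confined to this position can move the number beyond the scatter, with the counts of hydrogen-bond donors and acceptors and the net charge unchanged. No measurement here bears on the origin of the step.

From the compounds shown here alone, the entering group differs from the leaving one both in where the chlorine stands and in the added methyl, so the share of each in the step remains open. Also open, going by these compounds, is how this assay would respond at this position to a group carrying a nitrile or an amine in place of the chlorine.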